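Swapping one side group on compound 2

The source may hold more compounds than are shown below. What is called first, only, known or untested is meant among the compounds shown, and "the series" means these compounds.

Compound 1 `CS(=O)(=O)Nc1ccc(-n2cc(-c3ccccc3)nn2)cc1Oc1ccccc1` measures 14200 nM
Compound 2 `Cc1ccc(OCc2cn(-c3ccc(NS(C)(=O)=O)c(Oc4ccccc4)c3)nn2)cc1` measures 8200 nM

Both numbers come from a functional assay on DU-145 cells (Homo sapiens) for inhibition, read by MTT assay, with a stated time of 48 h; on this read-out higher numbers stand for weaker inhibition and lower numbers for stronger inhibition. With only these two values available, compound 2 cannot be separated from compound 1, since the two lie within the scatter of each other.

The next compound to be tested is compound 3 `CS(=O)(=O)Nc1ccc(-n2cc(OCc3ccccc3)nn2)cc1Oc1ccccc1`, which differs from compound 2 in one place: benzyloxy in place of (4-methylphenoxy)methyl on an aromatic carbon. In words, benzyloxy stands in place of (4-methylphenoxy)methyl on an aromatic carbon of a five-membered aromatic ring with 3 nitrogen.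

Within the data shown here, one measured step bears on this. It concerns the same place on the shared core. It is a 1.7-fold lower number from compound 1 to compound 2 (0.24 log units; within the scatter), with (4-methylphenoxy)methyl in place of phenyl. That exchange of large groups stayed within the scatter, so no step beyond the scatter is expected in this assay, and no direction can be favoured with confidence. Among the measured compounds shown here, no measured compound carries benzyloxy, so the range must stay wide.

The estimate implies an expected 1.2-fold higher number from compound 2 to compound 3 (0.09 log units; within the scatter) here.

For compound 3 the expected value is 10000 nM, with an estimated range from 4000 nM to 25000 nM.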

Compound 3, half-maximal inhibitory concentration: 10700 nM
Estimate against measurement, compound 3: 1.1-fold (0.03 log units) below, and the stated range covers the measured number.
By their numbers in this assay, from the lowest: compounds 2, 3 and 1 (each within the scatter of the next).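

Benzyloxy is a third large group at this place on the five-membered aromatic ring with 3 nitrogen, and it also leaves the number within the scatter, both against (4-methylphenoxy)methyl (a 1.3-fold higher number from compound 2 to compound 3 (0.12 log units; within the scatter)) and against phenyl (a 1.3-fold lower number from compound 1 to compound 3 (0.12 log units; within the scatter)). In this assay, then, compound 1, compound 2 and compound 3 cannot be told apart, even though their groups at this place differ in size and in how the six-membered aromatic ring of carbon only is attached. Among these compounds, the earlier pair offered only one such exchange, whereas these three compounds show the same lack of separation across three groups, though no measurement here explains it.

From the compounds shown here alone, all three groups carry that same kind of aromatic ring, so it remains unknown whether this place tolerates any change or only exchanges among groups of this kind. An amine, a carboxylic acid or a small methyl group at this place would test that, and the compounds shown cannot predict whether any of these would move the number beyond the scatter.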